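Swapping a Methoxynaphthyl for a Furan Ring

The source may report more compounds than this note shows. Statements on the series, on what has been measured and on what is new or still open speak of the compounds shown alone.

Compound 1 `N#CC1=C(N)N(c2ccc(S(N)(=O)=O)cc2)C2=C(C(=O)CCC2)C1/C=C/c1ccccc1`: 40%
Compound 2 `COc1cc(CC2C(C#N)=C(N)N(c3ccc(S(N)(=O)=O)cc3)C3=C2C(=O)CCC3)ccc1O`: 90%
Compound 3 `COc1ccc(C2C(C#N)=C(N)N(c3ccc(S(N)(=O)=O)cc3)C3=C2C(=O)CCC3)c2ccccc12`: 30%

All three compounds were tested in a functional assay on Ehrlich cells (Mus musculus) for antiproliferative activity, read by trypan blue exclusion, with a stated time of 2 h, tested at 50 ug/mL; a lower number here means a weaker effect, a higher number a stronger effect of the compound at the concentration tested. Compound 3 gives the lowest of the three numbers; its nearest neighbour is compound 1, and the step of a number 10 percentage points lower from compound 1 to compound 3 (within the scatter) is within the scatter, while the step of a number 60 percentage points lower from compound 2 to compound 3 (beyond the scatter) is large. Compound 4 `N#CC1=C(N)N(c2ccc(S(N)(=O)=O)cc2)C2=C(C(=O)CCC2)C1c1ccco1` differs from compound 3 by furan-2-yl in place of 4-methoxynaphthalen-1-yl on a saturated ring carbon. Among the compounds with values here, no measured step exchanges one directly attached aromatic ring for another small one, so the steps only bound the expectation: a direct aromatic ring on that carbon gave the low value of compound 3, a two-carbon-linked phenyl gave compound 1 a value within the scatter of it, and only the 4-hydroxy-3-methoxybenzyl of compound 2 gave a large number. Compound 4 is therefore expected to stay near the lower end, with an estimated step of a number 15 percentage points higher from compound 3 to compound 4 (beyond the scatter) of modest size. The estimate for compound 4 is 45%, ranging from 20% to 75%.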

Compound 4, a percentage reported as activity, at one concentration (the size of the read-out at that concentration, not a potency): 5%
Beside the measured number, compound 4's estimate is 40 percentage points above it; the measured number lies below the stated range.
By their numbers in this assay, from the lowest: compound 4; then compounds 3 and 1 (each within the scatter of the next); then compound 2.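

In this assay, furan-2-yl on this saturated ring carbon falls clearly short of the larger 4-methoxynaphthalen-1-yl (a number 25 percentage points lower from compound 3 to compound 4 (beyond the scatter)), so the two directly attached aromatic rings shown are not interchangeable here. Compound 4 also sits clearly under the compounds carrying the other two groups (a number 85 percentage points lower from compound 2 to compound 4 (beyond the scatter); a number 35 percentage points lower from compound 1 to compound 4 (beyond the scatter)), which makes it the lowest of the four and widens the range known for this one position. Nothing at hand explains why the furan-2-yl compound gives so low a number.

The compounds shown leave open whether a directly attached ring as small as furan-2-yl, such as thiophen-2-yl, would give a similar number. They also leave open whether a plain benzyl group, without the hydroxyl and methoxy, would keep the high number of compound 2.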